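A few compounds are considered here, and "the series" means these few. Any claim that something is new, unique, unknown or untested is made for them only; others in the source may bear on it.

Measured compounds and their values in a functional assay on the whole organism with Mus musculus as the target, in the writhing test; a lower number here means that less compound is needed, a higher number that more compound is needed for the effect:
Compound 1 `CCn1nc(C)c2c(C)cc(=O)oc21`: 24.9 mg/kg
Compound 2 `Cc1cc(O)oc2nnc(CC(=O)O)c1-2`: a limit of the assay, > 100 mg/kg
Compound 3 `CCOC(=O)Cc1nnc2oc(O)cc(C)c1-2`: a limit of the assay, > 100 mg/kg

Compound 2 stands only at a limit in this assay, and it shares that position with one other value, as the limit of > 100 mg/kg in this assay, at which 2 of the 3 values shown sit, shows. Among the compounds with values here, compound 1 is the sole compound with a number. The piece now follows the change from compound 2 to compound 4 `Cc1cc(O)oc2nncc1-2`: hydrogen in place of carboxymethyl on an aromatic carbon, in words hydrogen in place of carboxymethyl on an aromatic carbon.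

Within the data shown here, only one measured step touches that position: a step that the two limits leave unreadable from compound 2 to compound 3, where ethyl replaces hydrogen on an oxygen next to a carbonyl group. Its size is not readable because the limit of > 100 mg/kg in this assay, at which 2 of the 3 values shown sit, covers both of its ends. Among the measured compounds shown here, no measured step therefore gives a direction or a size for removing the carboxymethyl group, and compound 1, with its different core, offers no step to compound 2 or compound 4.

Compound 4 is accordingly estimated with wide bounds: its expected value in this assay is 60 mg/kg, between 20 mg/kg and 150 mg/kg. The estimated step is an at least 1.6-fold lower number from compound 2 to compound 4 (0.22 log units; that floor lies within the scatter), which is expected only as a guess, since compound 2 itself gives no number.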

Compound 4, dose for half-maximal effect: 40.6 mg/kg
Estimate against measurement, compound 4: 1.5-fold (0.17 log units) above; low and high end bracket the measured number.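

In this assay, within the data shown here, the aromatic carbon that carries carboxymethyl in compound 2 now gives the first step that can be read, and it is an at least 2.4-fold lower number from compound 2 to compound 4 (0.39 log units; beyond the scatter). Among these compounds, earlier, the only step at this side chain, ethyl in place of hydrogen on the oxygen of the carboxymethyl group, could not be read, so nothing showed whether this position affects the dose needed; replacing the whole group with hydrogen shows that it does, and that the compound without the group needs less. The step is only a floor and not a full size because compound 2 stands at a limit: the limit of > 100 mg/kg in this assay, at which 2 of the 4 values shown sit.

The compounds shown go from the full carboxymethyl group straight to hydrogen, so they do not tell whether a group of intermediate size, such as a methyl group, or a different one, such as an amine, on this aromatic carbon would stay close to compound 4 or move back towards compound 2. They also leave open how much of the step belongs to the chain itself and how much to the carboxylic acid at its end.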